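Swapping the bromophenyl for a methylphenyl on the ketone

The source may hold more compounds than are shown below. What is called first, only, known or untested is meant among the compounds shown, and "the series" means these compounds.

Of the compounds shown here, three of a shared core have been measured in a functional assay on Ehrlich cells (Mus musculus) for cytotoxicity, read by trypan blue exclusion, with a stated time of 48 h; a higher number here means a weaker inhibitor, a lower number a stronger inhibitor. Compound 1 `COc1ccc(C(=O)c2cc(C)ccc2OCC(=O)NNC(=O)c2cc3ccccc3oc2=O)cc1` gives 41200 nM, compound 2 `Cc1ccc(OCC(=O)NNC(=O)c2cc3ccccc3oc2=O)c(C(=O)c2ccccc2)c1` gives 86500 nM, and compound 3 `Cc1ccc(OCC(=O)NNC(=O)c2cc3ccccc3oc2=O)c(C(=O)c2cccc(Br)c2)c1` gives 68500 nM; compound 3 thus sits between the other two, within the scatter of both. Compound 4 `Cc1ccc(C(=O)c2cc(C)ccc2OCC(=O)NNC(=O)c2cc3ccccc3oc2=O)cc1` carries 4-methylphenyl in place of 3-bromophenyl on a carbonyl carbon. The closest measured steps are a 1.7-fold higher number from compound 1 to compound 3 (0.22 log units; within the scatter) and a 1.3-fold lower number from compound 2 to compound 3 (0.10 log units; within the scatter), both small, while a 2.1-fold higher number from compound 1 to compound 2 (0.32 log units; beyond the scatter) was modest. Taken together, these suggest that changing the group on this carbonyl carbon shifts the number only slightly, so compound 4 is expected to land near compound 3, with perhaps a slightly lower number: a 1.2-fold lower number from compound 3 to compound 4 (0.10 log units; within the scatter). The estimate for compound 4 in this assay is 55000 nM, within a range from 25000 nM to 120000 nM.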

Compound 4, half-maximal inhibitory concentration: 82600 nM
Compound 4: the middle estimate sits 1.5-fold (0.18 log units) below what was measured; low and high end bracket the measured number.
By their numbers in this assay, from the lowest: compounds 1, 3, 4 and 2 (each within the scatter of the next, the first and the last beyond it).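

In this assay the change from 3-bromophenyl to 4-methylphenyl on this carbonyl carbon gives a 1.2-fold higher number from compound 3 to compound 4 (0.08 log units; within the scatter) and adding a methyl group to the aromatic ring gives a 1.0-fold lower number from compound 2 to compound 4 (0.02 log units; within the scatter) so neither change separates its pair. Methyl in place of methoxy gives a 2.0-fold higher number from compound 1 to compound 4 (0.30 log units; within the scatter) and thus also stays inside the scatter, leaving hydrogen in place of methoxy, with a 2.1-fold higher number from compound 1 to compound 2 (0.32 log units; beyond the scatter) as the only step here beyond it. Nothing available explains these results.

Going by these compounds, whether an amine or a carboxylic acid on this aromatic ring would move the number further remains open.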